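This account rests on a few compounds, and the source may have more. Where it says the series, first, only, none or still open, it means among the compounds named here.

Measured compounds in the series:
- compound 1 `COc1ccccc1CNc1ncnc2c1ncn2[C@@H]1O[C@H](CO)[C@@H](O)[C@H]1O`: 140000 nM
- compound 2 `OC[C@H]1O[C@@H](n2cnc3c(NCc4cc(F)cc(F)c4)ncnc32)C(O)C1O`: > 166000 nM (a limit of the assay, not a number)

In an ADME assay on NIH3T3 cells (Mus musculus) for cytotoxicity, with a stated time of 72 h (on this read-out lower numbers stand for stronger inhibition and higher numbers for weaker inhibition), compound 1 gives 140000 nM, the only numerical result so far in the set. Compound 2 reaches only the limit of > 166000 nM in this assay, at which 1 of the 2 values shown sits, in this assay, so no number is known for it. Among the measured compounds shown here, compound 1 therefore stands as the single measured point, and with the other result being a limit, no step between measured compounds can be drawn and no ordering can be stated.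

The next compound, compound 3 `OC[C@H]1O[C@@H](n2cnc3c(NCc4ccc(F)cc4Cl)ncnc32)[C@H](O)[C@@H]1O`, differs from compound 1 in one place: 2-chloro-4-fluorophenyl in place of 2-methoxyphenyl on a saturated chain carbon bound to a nitrogen on an aromatic ring. Both the leaving and the entering group are of the same size and sit on the same carbon, and the shared core is unchanged. With nothing measured beyond compound 1 and a limit for compound 2, there is no basis for expecting a shift beyond the scatter in either direction; the step from compound 1 to compound 3 is expected to be close to none, a 1.1-fold higher number from compound 1 to compound 3 (0.03 log units; within the scatter). Compound 3 is accordingly estimated at 150000 nM in this assay, in a range from 60000 nM to 350000 nM, with a real chance that only a limit is reported.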

Compound 3, half-maximal inhibitory concentration: > 166000 nM
Compound 3 gave a limit, no number; the forecaster's own chance of this, stated with the estimate: 45%; middle value at least 1.1-fold (0.04 log units) from the limit.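

In this assay, among the compounds shown here, the first one-place comparison, 2-chloro-4-fluorophenyl in place of 2-methoxyphenyl on a saturated chain carbon bound to a nitrogen on an aromatic ring, gives an at least 1.1-fold higher number from compound 1 to compound 3 (0.07 log units; that floor lies within the scatter). From the compounds shown here alone, the result for compound 3 is a limit of the assay, not a number, so only the floor of this step can be read, and its true size remains unknown; the exchange of a group with 1 hydrogen-bond acceptor for one with 0 brings no lower number in this assay. The series now rests mostly on limits: the limit of > 166000 nM in this assay, at which 2 of the 3 values shown sit.

Going by these compounds, whether the real step from 2-methoxybenzyl to 2-chloro-4-fluorobenzyl lies within or beyond the scatter stays open, and the chlorine and the fluorine cannot be told apart because they enter together. Also open, on these data alone, is whether a group such as an amine or a carboxylic acid on the phenyl ring, or a longer chain in this place, would bring a lower number on the shared core.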